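A Piperazine Chain in Place of the Triazole

The source may report more compounds than this note shows. Statements on the series, on what has been measured and on what is new or still open speak of the compounds shown alone.

Measured in a functional assay on MDA-MB-231 cells (Homo sapiens) for cytotoxicity, read by MTT assay, with a stated time of 72 h; a lower number here means a stronger inhibitor, a higher number a weaker inhibitor:
compound 1 `O=C1c2c[n+]([O-])c3ccccc3c2C(=O)c2c1c1ccccc1n2Cc1cn(C[C@H](O)CO)nn1`: 1310 nM
compound 2 `O=C1c2c[n+]([O-])c3ccccc3c2C(=O)c2c1c1ccccc1n2Cc1cn(CC(O)CO)nn1`: 1290 nM

On these numbers, compound 2 at 1290 nM stands level with compound 1, and a 1.0-fold lower number from compound 1 to compound 2 (0.01 log units; within the scatter) lies within the scatter. Compound 3 `CN1CCN(CCCCn2c3c(c4ccccc42)C(=O)c2c[n+]([O-])c4ccccc4c2C3=O)CC1` has yet to be measured in this assay. It carries 3-(4-methylpiperazin-1-yl)propyl in place of 1-(2,3-dihydroxypropyl)-1H-1,2,3-triazol-4-yl, on a saturated chain carbon bound to an aromatic nitrogen: 3-(4-methylpiperazin-1-yl)propyl in place of 1-(2,3-dihydroxypropyl)-1H-1,2,3-triazol-4-yl on a saturated chain carbon bound to an aromatic nitrogen. For the measured compounds named here, the one measured step, a 1.0-fold lower number from compound 1 to compound 2 (0.01 log units; within the scatter), concerns only (the fact that one of compounds 1 and 2 is drawn with a defined configuration and the other without, at the place where they differ), so it says nothing about this exchange of groups. Going by the values given here, no measured step gives a size or direction for the change, so no step beyond the scatter is expected, though with wide uncertainty. The expected step is a 1.4-fold lower number from compound 2 to compound 3 (0.16 log units; within the scatter). For compound 3 the estimated value is 900 nM, with an expected range from 200 nM to 4000 nM.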

Compound 3, half-maximal inhibitory concentration: 110 nM
Compound 3: the middle estimate sits 8.2-fold (0.91 log units) above what was measured, and the stated range ends above it.
By their numbers in this assay, from the lowest: compound 3; then compounds 2 and 1 (each within the scatter of the next).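

In this assay, putting 3-(4-methylpiperazin-1-yl)propyl in place of 1-(2,3-dihydroxypropyl)-1H-1,2,3-triazol-4-yl on a saturated chain carbon bound to an aromatic nitrogen gives a 12-fold lower number from compound 2 to compound 3 (1.07 log units; beyond the scatter) and likewise a 12-fold lower number from compound 1 to compound 3 (1.08 log units; beyond the scatter) for the compound with the drawn configuration. For the compounds shown here, the earlier pair differed only in how a stereocentre was drawn, so this is the first sign that the number responds to the group carried at this position, and the two groups hold the same number of heavy atoms. Nothing measured here bears on why the number falls.

The exchange replaces the whole group at once, so the compounds shown do not separate the contribution of the 4-methylpiperazin-1-yl ring from that of the chain carrying it. As far as these compounds go, a morpholine or a dimethylamine at the end of the chain, or a shorter or longer chain, remains open.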